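A methyl on the phenyl ring of compound 2

The source may report more compounds than this note shows. Statements on the series, on what has been measured and on what is new or still open speak of the compounds shown alone.

Compound 2 `COc1cc(C(F)(F)F)cc(SC)c1C(=O)NC1(c2ccccc2)CCCN(C)C1` gives 24 nM in an assay on cells for inhibition of sodium- and chloride-dependent glycine transporter 1 (Homo sapiens); on this read-out lower numbers stand for an effect already at smaller amounts and higher numbers for an effect only at larger amounts of compound. Among the three measured compounds it holds the second-highest number: compound 3 `COc1cc(C(F)(F)F)cc(SC)c1C(=O)N[C@@]1(c2ccccc2)CCCN(C)C1` gives 10 nM, and compound 1 `CSc1cc(C(F)(F)F)ccc1C(=O)NC1(c2ccccc2)CCCN(C)C1` gives 67 nM. Both measured steps lie elsewhere on the structure: a 2.8-fold lower number from compound 1 to compound 2 (0.45 log units; beyond the scatter), and a 2.4-fold lower number from compound 2 to compound 3 (0.38 log units; beyond the scatter), the latter going with the fact that one of compounds 2 and 3 is drawn with a defined configuration and the other without, at the place where they differ. Compound 4 `COc1cc(C(F)(F)F)cc(SC)c1C(=O)NC1(c2ccc(C)cc2)CCCN(C)C1` differs from compound 2 by methyl in place of hydrogen on an aromatic carbon. Among the compounds with values here, no measured step touches the phenyl ring, so nothing in these data argues for a change beyond the scatter in either direction. Compound 4 is therefore expected to give 24 nM (range 8 nM to 70 nM), a step of no change at the digits printed from compound 2 to compound 4 (within the scatter) that is estimated to stay within the scatter.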

Compound 4, half-maximal effective concentration: 230 nM
The estimate for compound 4 lay 9.6-fold (0.98 log units) below the measured number; measured number outside the range, above it.
By their numbers in this assay, from the lowest: compound 3; then compound 2; then compound 1; then compound 4.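

The phenyl ring of the shared core is not indifferent to substitution: in this assay, going from phenyl to 4-methylphenyl gives a 9.6-fold higher number from compound 2 to compound 4 (0.98 log units; beyond the scatter), the largest step among those shown. A single added methyl, para to a large group, thus places compound 4 highest of the four. Nothing given here bears on why this step occurs.

The compounds shown leave open whether a fluorine, a chlorine or a hydroxyl on this carbon would give a similar rise. Also open, from the compounds shown here alone, is whether the rise would hold for the configuration drawn in compound 3.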